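Hexyl to octyl: compound 3 to compound 4

A few compounds are considered here, and "the series" means these few. Any claim that something is new, unique, unknown or untested is made for them only; others in the source may bear on it.

Measured in a functional assay, with a stated time of 10 min (a lower number here means a stronger inhibitor, a higher number a weaker inhibitor), so far:
compound 1 `CCCCCCCCOc1cc(OC)c(Br)cc1C(C)=O` gives 38100000 nM
compound 2 `CCOc1cc(OC)ccc1C(C)=O` gives 35300000 nM
compound 3 `CCCCCCOc1cc(OC)ccc1C(C)=O` gives 84400000 nM

Compound 3 has the highest number of the three, beyond the scatter from both compound 1 and compound 2, which makes it the weakest inhibitor so far. Compound 4 `CCCCCCCCOc1cc(OC)ccc1C(C)=O` is the next case, with this change from compound 3: ethyl in place of hydrogen on a saturated chain carbon, six bonds along the chain from an oxygen on an aromatic ring. Among the compounds with values here, the one measured step along the chain is a 2.4-fold higher number from compound 2 to compound 3 (0.38 log units; beyond the scatter), a modest rise with a butyl added. The ethyl added here is smaller than that butyl, so a smaller rise is expected if the same trend holds. Compound 1 carries an octyl chain and reads 38100000 nM, which speaks against a large further rise, although its added bromine on the core makes it an imperfect comparison. In this assay the expected change is small and upward, not beyond the scatter. The estimated step is a 1.2-fold higher number from compound 3 to compound 4 (0.07 log units; within the scatter). The expected value for compound 4 is 100000000 nM, with an estimated range of 45000000 nM to 200000000 nM.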

Compound 4, half-maximal inhibitory concentration: 69400000 nM
Compound 4: middle estimate off by 1.4-fold (0.16 log units), on the high side, and the stated range covers the measured number.
By their numbers in this assay, from the lowest: compounds 2, 1, 4 and 3 (each within the scatter of the next, the first and the last beyond it).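

Ethyl in place of hydrogen at this chain carbon leaves hexyl and octyl indistinguishable in this assay (a 1.2-fold lower number from compound 3 to compound 4 (0.08 log units; within the scatter)), so the rise seen with butyl (a 2.4-fold higher number from compound 2 to compound 3 (0.38 log units; beyond the scatter)) does not carry on as a further step along the chain. Hexyl in place of hydrogen on the ethyl chain stays within the scatter (a 2.0-fold higher number from compound 2 to compound 4 (0.29 log units; within the scatter)), which means the full stretch from ethyl to octyl cannot be separated, although the stretch from ethyl to hexyl can. With the octyl chain held, hydrogen in place of bromo on the aromatic carbon also stays within the scatter (a 1.8-fold higher number from compound 1 to compound 4 (0.26 log units; within the scatter)), so bromo makes no readable difference here.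

On these data alone, whether a methyl group or a chain ending in an amine or a carboxylic acid would shift the number beyond the scatter remains open. No supporting data bear on the reason for these steps.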